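Para substituent swap on the sulfonyl ring: chloro to acetamido

The compounds below may be only part of what the source reports. "The series", "measured", "known", "first", "only" and "open" are said of these compounds alone.

Measured so far in a functional assay on HepG2 cells (Homo sapiens) for cytotoxicity, read by MTT assay, with a stated time of 24 h; a higher number here means a weaker inhibitor, a lower number a stronger inhibitor:
Compound 1 `O=C1/C(=C/c2ccccc2F)CN(S(=O)(=O)c2ccc(C(F)(F)F)cc2)C/C1=C\c1ccccc1F` gives 4900 nM.
Compound 2 `O=C1/C(=C/c2ccccc2F)CN(S(=O)(=O)c2ccc(F)cc2)C/C1=C\c1ccccc1F` gives 8000 nM.
Compound 3 `O=C1/C(=C/c2ccccc2F)CN(S(=O)(=O)c2ccc(Cl)cc2)C/C1=C\c1ccccc1F` gives 10900 nM.

Compound 3 sits at the upper end of the three numbers. Its gap to compound 2 is small, a 1.4-fold higher number from compound 2 to compound 3 (0.13 log units; within the scatter), so the two are not distinguishable here. Its gap to compound 1 is larger, a 2.2-fold higher number from compound 1 to compound 3 (0.35 log units; beyond the scatter), a modest step. The remaining step, a 1.6-fold higher number from compound 1 to compound 2 (0.21 log units; within the scatter), is also small. All three compounds share the same core and differ only in the group on the sulfonyl ring, and the whole spread across them is narrow.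

Compound 4 `CC(=O)Nc1ccc(S(=O)(=O)N2C/C(=C\c3ccccc3F)C(=O)/C(=C/c3ccccc3F)C2)cc1` carries the same core with the change (acetamido in place of chloro on an aromatic carbon). Within the data shown here, no measured step involves an acetamido group, so the three halogen and trifluoromethyl swaps bear on it only by showing that changes at this position have moved the number little. On that basis the step from compound 3 to compound 4 is expected to stay small, a 1.1-fold higher number from compound 3 to compound 4 (0.04 log units; within the scatter), with no confident direction. Compound 4 is therefore estimated at 12000 nM in this assay, with a range of 5000 nM to 30000 nM.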

Compound 4, half-maximal inhibitory concentration: 5200 nM
Compound 4: the middle estimate sits 2.3-fold (0.36 log units) above what was measured, within the range that was stated.
By their numbers in this assay, from the lowest: compounds 1, 4, 2 and 3 (each within the scatter of the next, the first and the last beyond it).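

Acetamido is the first group at this position with a hydrogen-bond donor and acceptor, and at 4 heavy atoms it is larger than chloro, yet in this assay the swap for chloro gives a 2.1-fold lower number from compound 3 to compound 4 (0.32 log units; beyond the scatter). The other two comparisons give a 1.5-fold lower number from compound 2 to compound 4 (0.19 log units; within the scatter) and a 1.1-fold higher number from compound 1 to compound 4 (0.03 log units; within the scatter), so compound 4 cannot be told apart from compound 2 or compound 1, and among the four compounds only compound 3 stands apart from compound 1 and compound 4. The position therefore accepts a group of quite a different kind from the halogens and trifluoromethyl with no rise in the number, though nothing at hand accounts for the step from chloro to acetamido.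

The compounds shown do not separate the contribution of the amide hydrogen from that of the carbonyl, which a free amine or a methoxy group at this position could help to address. Also open, going by these compounds, is how far the position stays this permissive with a longer acyl chain, a carboxylic acid or a basic amine on a chain.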